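Amide for nitrile at the chain end of compound 2

A few compounds are considered here, and "the series" means these few. Any claim that something is new, unique, unknown or untested is made for them only; others in the source may bear on it.

The shared core is that of compound 1 `CCc1cc(C(C)=O)c(O)cc1OCCCCCCC#N`. In an assay on isolated protein for inhibition of leukotriene B4 receptor 1 (Homo sapiens), tested at 10 uM (on this read-out lower numbers stand for less inhibition and higher numbers for more inhibition at the one concentration tested (going by the name of the read-out)), compound 1 gives 103%. Compound 2 `C=CCc1cc(C(C)=O)c(O)cc1OCCCCCCCC#N` gives 88% in this assay, and compound 3 `CCc1cc(C(C)=O)c(O)cc1OCCCCCC(C)(C)C#N` gives 85%. On these three numbers compound 2 stands second highest: its nearest neighbour is compound 3, within the scatter, while the gap to compound 1 lies beyond it. For the measured compounds named here, the only measured step at the far end of the chain is a number 18 percentage points lower from compound 1 to compound 3 (beyond the scatter), in which 1-cyano-1-methylethyl replaces cyanomethyl. Compound 4 `C=CCc1cc(C(C)=O)c(O)cc1OCCCCCC(=O)N(C)C` differs from compound 2 by dimethylcarbamoyl in place of 2-cyanoethyl on a saturated chain carbon, five bonds along the chain from an oxygen on an aromatic ring. Going by the values given here, no measured step exchanges the nitrile for an amide; the step from compound 1 to compound 3 is the sole guide to a change at this end of the chain, and it cost a modest amount. A modest loss is therefore expected, a number 13 percentage points lower from compound 2 to compound 4 (beyond the scatter), with no firm basis for more. Compound 4 is estimated at 75% in this assay, in the range 50% to 95%.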

Compound 4, a percentage reported as inhibition, at one concentration (the size of the read-out at that concentration, not a potency): 92%
The estimate for compound 4 lay 17 percentage points below the measured number; the measured number falls inside the stated range.
By their numbers in this assay, from the lowest: compounds 3, 2 and 4 (each within the scatter of the next); then compound 1.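

In this assay, a number 4 percentage points higher from compound 2 to compound 4 (within the scatter), so at this place, on a saturated chain carbon five bonds along the chain from an oxygen on an aromatic ring, the nitrile can give way to dimethylcarbamoyl without a readable change. For the compounds shown here, the only earlier step at this end, a number 18 percentage points lower from compound 1 to compound 3 (beyond the scatter), kept the nitrile, whereas this one removes it and shows that the read-out at the one concentration tested does not depend on a nitrile in this pair. No measurement at hand bears on the reason for this result.

Still open, as far as these compounds go, is how a carboxylic acid, a primary amide or an amine would read at this chain end. Also open, from the compounds shown here alone, is whether a longer chain ending in dimethylcarbamoyl would hold the number seen for compound 4.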